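A few compounds are considered here, and "the series" means these few. Any claim that something is new, unique, unknown or untested is made for them only; others in the source may bear on it.

Measured so far in a functional assay on A549 cells (Homo sapiens) for antiproliferative activity, read by MTT assay, with a stated time of 24 h; a lower number here means a stronger inhibitor, a higher number a weaker inhibitor:
compound 1 `O=c1[nH]cc(S(=O)(=O)Nc2ccc(-c3cn(-c4ccccc4)nn3)cc2)c(=O)[nH]1` gives 7170 nM
compound 2 `O=c1[nH]cc(S(=O)(=O)Nc2ccc(-c3cn(-c4ccccc4F)nn3)cc2)c(=O)[nH]1` gives 5960 nM
compound 3 `O=c1[nH]cc(S(=O)(=O)Nc2ccc(-c3cn(-c4ccccc4Cl)nn3)cc2)c(=O)[nH]1` gives 2810 nM

Compound 3 stands lowest of the three numbers in this assay: the step of a 2.6-fold lower number from compound 1 to compound 3 (0.41 log units; beyond the scatter) and the step of a 2.1-fold lower number from compound 2 to compound 3 (0.33 log units; beyond the scatter) are both modest but beyond the scatter, while a 1.2-fold lower number from compound 1 to compound 2 (0.08 log units; within the scatter) stays within it. Compound 4 `O=c1[nH]cc(S(=O)(=O)Nc2ccc(-c3cn(-c4ccc(Cl)cc4)nn3)cc2)c(=O)[nH]1` keeps every atom of compound 3 and changes only (4-chlorophenyl in place of 2-chlorophenyl on an aromatic nitrogen). Within the data shown here, none of the measured steps bears directly on this change: each of them swaps the group at one position, none moves a group from one position to another. The data give no direction for this change, so the expected step is a 1.0-fold lower number from compound 3 to compound 4 (0.00 log units; within the scatter), an estimate with no step beyond the scatter. Compound 4 is accordingly estimated at 2800 nM, within 1100 nM to 7500 nM.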

Compound 4, half-maximal inhibitory concentration: 1210 nM
For compound 4 the middle estimate is 2.3-fold (0.36 log units) above the measured one; the range from low to high includes it.
By their numbers in this assay, from the lowest: compound 4; then compound 3; then compounds 2 and 1 (each within the scatter of the next).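

In this assay the place of the chloro on the phenyl group on the aromatic nitrogen matters, and not only its presence: 4-chlorophenyl in place of 2-chlorophenyl gives a 2.3-fold lower number from compound 3 to compound 4 (0.37 log units; beyond the scatter) with the same atoms. The 4-chlorophenyl group also gives a 4.9-fold lower number from compound 2 to compound 4 (0.69 log units; beyond the scatter) and a 5.9-fold lower number from compound 1 to compound 4 (0.77 log units; beyond the scatter) as the two largest steps in this set. Nothing available explains why the two chlorophenyl groups differ.

Going by these compounds, whether a fluoro shifted in the same way would also lower the number remains open. So does the outcome with a methoxy group, an amine or a carboxylic acid on that phenyl.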